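Swapping the aryl group on the shared core: compound 4

A few compounds are considered here, and "the series" means these few. Any claim that something is new, unique, unknown or untested is made for them only; others in the source may bear on it.

Measured compounds:
- compound 1 `COc1cc(NC(=O)Nc2cc(Nc3ccc(OC)c(C)c3)ncn2)cc(OC)c1`: 62%
- compound 2 `COc1cc(NC(=O)Nc2cc(Nc3cccc(C(C)(C)C)c3)ncn2)cc(OC)c1`: 68%
- compound 3 `COc1cc(NC(=O)Nc2cc(Nc3ccc(F)c(Cl)c3)ncn2)cc(OC)c1`: 77.5%

Three compounds share one core and differ only in the aryl group on a nitrogen on an aromatic ring. In a functional assay on PC-9 cells (Homo sapiens) for inhibition, read by MTT assay, with a stated time of 48 h, tested at 10 uM (a higher number here means more inhibition at the concentration tested (going by the name of the read-out), a lower number less inhibition), compound 1 gives 62%, compound 2 gives 68% and compound 3 gives 77.5%. Compound 3 has the highest number of the three, but only its gap to compound 1 is beyond the scatter: a number 15.5 percentage points higher from compound 1 to compound 3 (beyond the scatter), while a number 9.5 percentage points higher from compound 2 to compound 3 (within the scatter) and a number 6 percentage points higher from compound 1 to compound 2 (within the scatter).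

Compound 4 `COc1cc(NC(=O)Nc2cc(Nc3ccc(Br)cc3OC)ncn2)cc(OC)c1` has not yet been measured. It differs from compound 3 at the same place as the steps above: 4-bromo-2-methoxyphenyl in place of 3-chloro-4-fluorophenyl on a nitrogen on an aromatic ring. The two steps that bear on this change both end at compound 3, and they show that exchanging this aryl group can move this assay by a modest amount or not at all. Among the measured compounds shown here, compound 1, the one compound carrying a methoxy-bearing aryl group, gave the lowest number, so a small fall is expected: the step of a number 12.5 percentage points lower from compound 3 to compound 4 (beyond the scatter) is the estimate here. Compound 4 is expected to give about 65%, within 45% to 82%.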

Compound 4, a percentage reported as inhibition, at one concentration (the size of the read-out at that concentration, not a potency): 83%
For compound 4 the middle estimate is 18 percentage points below the measured one; measured number outside the range, above it.
By their numbers in this assay, from the lowest: compounds 1, 2, 3 and 4 (each within the scatter of the next, the first and the last beyond it).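

In this assay the change to 4-bromo-2-methoxyphenyl gives a number 5.5 percentage points higher from compound 3 to compound 4 (within the scatter) and so leaves the new aryl group level with 3-chloro-4-fluorophenyl. The new group also stands clear of the other two aryl groups, with a number 15 percentage points higher from compound 2 to compound 4 (beyond the scatter) and with a number 21 percentage points higher from compound 1 to compound 4 (beyond the scatter) at this same position. Compound 1 and compound 4 both carry a methoxy group on the aryl ring yet lie at opposite ends of the series, so among these compounds a methoxy group does not by itself go with a low number.

No measurement available explains why these aryl groups differ. Also open, on these data alone, is how an aryl group carrying an amine or a carboxylic acid would compare, and with only one tested concentration, how compound 3 and compound 4 differ in potency.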